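The compounds below may be only part of what the source reports. "The series", "measured", "known", "first", "only" and "open" are said of these compounds alone.

Working notes on the series. In a functional assay on L1210 cells (Mus musculus) for inhibition, read by cell counting, with a stated time of 2 days (a higher number here means a weaker inhibitor, a lower number a stronger inhibitor), compound 1 `Nc1cccc(-c2cn3nc(-c4cccs4)sc3n2)c1` returns only a limit, > 250000 nM. Compound 3 `COc1cccc(-c2nn3cc(-c4cccc(N)c4)nc3s2)c1` likewise returns only a limit, > 250000 nM. For the measured compounds named here, compound 2 `COc1ccc(-c2csc3nc(-c4cccc(N)c4)cn23)cc1` is the one member with a number, 19000 nM. Compound 1 therefore stands at the limit of > 250000 nM in this assay, at which 2 of the 3 values shown sit, with no number of its own to build on. Compound 4 `Nc1cccc(-c2cn3nc(-c4ccc(F)cc4)sc3n2)c1` has not been measured; it differs from compound 1 by 4-fluorophenyl in place of thiophen-2-yl on an aromatic carbon. Going by the values given here, no measured pair differs in one place, so the size of this change has no precedent here. In this assay the step of an at least 1.2-fold lower number from compound 1 to compound 4 (0.09 log units; that floor lies within the scatter) is expected to be small, none beyond the scatter, most likely ending again at the limit. Compound 4 is estimated at 200000 nM, within 40000 nM to 1000000 nM.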

Compound 4, half-maximal inhibitory concentration: >= 250000 nM
Compound 4: no number, only a limit; the forecaster's own chance of this, stated with the estimate: 65%; at least 1.2-fold (0.09 log units) between middle value and limit.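

Compound 1 and compound 4 both return only limits, so the step between them cannot be read. The compounds shown leave open whether 4-fluorophenyl in place of thiophen-2-yl changes the read-out at all.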